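The source may hold more compounds than are shown below. What is called first, only, known or untested is meant among the compounds shown, and "the series" means these compounds.

Measured so far in a functional assay on A549 cells (Homo sapiens) for cytotoxicity, read by MTT assay, with a stated time of 68 h; a lower number here means a stronger inhibitor, a higher number a weaker inhibitor: compound 1 `O=C(Nc1cccc(-c2ccccc2C(F)(F)F)c1)C(Cl)Cl` gives 7500 nM; compound 2 `O=C(Nc1cccc(-c2ccccc2F)c1)C(Cl)Cl` gives 13200 nM; compound 3 `O=C(Nc1cccc(-c2ccc(F)cc2)c1)C(Cl)Cl` gives 7840 nM.

Compound 1 differs from compound 2 by one change, (trifluoromethyl in place of fluoro on an aromatic carbon), and that change made a step of a 1.8-fold lower number from compound 2 to compound 1 (0.25 log units; within the scatter) in this assay. Compound 3 is built from the same atoms as compound 2 joined differently; the difference between the two cores is not broken down here. Compound 4 `O=C(Nc1cccc(-c2ccc(C(F)(F)F)cc2)c1)C(Cl)Cl`, not yet measured, arises from compound 3 by trifluoromethyl in place of fluoro on an aromatic carbon. Among the measured compounds shown here, this is the same kind of change as the one from compound 2 to compound 1, though the place differs: there the group entered ortho to a large group, here it enters para to a large group. Resting on the step of a 1.8-fold lower number from compound 2 to compound 1 (0.25 log units; within the scatter), compound 4 is expected to show a step of a 1.4-fold lower number from compound 3 to compound 4 (0.15 log units; within the scatter) in this assay. Compound 4 is therefore estimated at 5500 nM, between 2500 nM and 12000 nM.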

Compound 4, half-maximal inhibitory concentration: 23500 nM
For compound 4 the middle estimate is 4.3-fold (0.63 log units) below the measured one, outside the stated range (above it).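

In this assay, trifluoromethyl in place of fluoro on an aromatic carbon, para to a large group, gave a 3.0-fold higher number from compound 3 to compound 4 (0.48 log units; beyond the scatter). Set beside the earlier step, this shows that the result of the change on one core does not foretell its result on the other: the same change on two cores in this assay, a 1.8-fold lower number (0.25 log units; within the scatter) from compound 2 to compound 1 and a 3.0-fold higher number (0.48 log units; beyond the scatter) from compound 3 to compound 4, 5.3-fold (0.72 log units) apart, beyond the scatter of two such steps. It does not show whether the core or the place of the group governs the step, since the two pairs differ in both, and two pairs set no rule for the series.

The compounds shown leave open how chloro, methyl or methoxy in the same place would compare with fluoro and trifluoromethyl. They also leave open what trifluoromethyl would do on another carbon of that ring.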